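A few compounds are considered here, and "the series" means these few. Any claim that something is new, unique, unknown or untested is made for them only; others in the source may bear on it.

In an ADME assay on microsomes from liver (Homo sapiens) for metabolic stability, read by LC-MS, with a stated time of 40 min, tested at 0.5 uM (on this read-out lower numbers stand for slow clearance and higher numbers for fast clearance), compound 1 `O=C(Nc1cccc(S(=O)(=O)C2CCCC2)c1)c1cccnc1N1CCC(F)(F)CC1` gives > 399 mL.min-1.g-1, which is a limit and not a number. Compound 2 `CC1(C)CCN(c2ncccc2C(=O)Nc2cccc(S(=O)(=O)C3CCCC3)c2)CC1` gives > 399 mL.min-1.g-1, also a limit. Compound 3 `O=C(Nc1cccc(S(=O)(=O)C2CCCC2)c1)c1cccnc1N1CCC2(CC1)CC2` gives > 399 mL.min-1.g-1, again a limit, so it stands with the other two: the limit of > 399 mL.min-1.g-1 in this assay, at which 3 of the 3 values shown sit. Compound 4 `O=C(Nc1cccc(S(=O)(=O)C2CCCC2)c1)c1cccnc1N1CCCCC1` differs from compound 3 in one group: a group of 6 heavy atoms (5 carbon, 1 nitrogen; one six-membered non-aromatic ring with 1 hetero atom) in place of a group of 8 heavy atoms (7 carbon, 1 nitrogen; one three-membered non-aromatic ring of carbon only, one six-membered non-aromatic ring with 1 hetero atom), on an aromatic carbon. Among the measured compounds shown here, three measured steps bear on this change, a step that the two limits leave unreadable from compound 1 to compound 2, a step that the two limits leave unreadable from compound 1 to compound 3 and a step that the two limits leave unreadable from compound 2 to compound 3. None of them has a readable size, so no step beyond the usual scatter is expected in this assay, in either direction. The estimated step is a step that the limit leaves unreadable from compound 3 to compound 4. The estimate for compound 4 is 400 mL.min-1.g-1, with an expected range from 200 mL.min-1.g-1 to 700 mL.min-1.g-1.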

Compound 4, intrinsic clearance in microsomes: > 399 mL.min-1.g-1
Compound 4 ended at the assay's limit; the forecaster's own chance of this, stated with the estimate: 70%; the middle value does not contradict the limit.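

Compound 4, like compounds 1, 2 and 3, gives only a limit and not a number, so no step among these four compounds can be read: the limit of > 399 mL.min-1.g-1 in this assay, at which 4 of the 4 values shown sit.

Whether the groups that set these compounds apart differ at all in this assay stays open among the compounds shown.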